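Stereochemical variation within a saturated bicyclic ether series

A few compounds are considered here, and "the series" means these few. Any claim that something is new, unique, unknown or untested is made for them only; others in the source may bear on it.

Among the compounds with values here, compound 1 `C[C@@H]1CC[C@@H]2[C@@H](C1)OC(C)(C)C[C@]2(C)O` is the only compound with a number in an ADME assay on MDCK cells (Canis lupus familiaris) for cytotoxicity, read by MTT assay, with a stated time of 48 h; a lower number here means that less compound is tolerated, a higher number that more compound is tolerated: compound 1 gives 816000 nM. Compound 2 `CCC[C@H]1C[C@@](C)(O)[C@@H]2CC[C@@H](C)C[C@H]2O1` reaches only a limit in this assay, and compound 2 gives > 1320000 nM, which is a limit and not a number (the limit of > 1320000 nM in this assay, at which 1 of the 2 values shown sits). Compound 3 `C[C@@H]1CC[C@@H]2[C@H](C1)OC(C)(C)CC2(C)O` is not yet measured and differs from compound 1 by the two compounds have the same atoms and bonds; at least one stereo element is drawn with a configuration in one of them and without one in the other: 2 of 4 stereo elements differ; a stereocentre at a saturated ring carbon is drawn R in compound 1 and S in compound 3; a stereocentre at a saturated ring carbon is drawn S in compound 1 and without a configuration in compound 3. No step between measured compounds is shown that would calibrate such a change, so the step of a 1.1-fold higher number from compound 1 to compound 3 (0.04 log units; within the scatter) is expected to stay within the usual scatter, in no particular direction. Compound 3 is therefore estimated at 900000 nM, with a range from 400000 nM to 2000000 nM. A limit-only read-out for compound 3 remains plausible.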

Compound 3, half-maximal cytotoxic concentration: 72200 nM
The estimate for compound 3 lay 12-fold (1.10 log units) above the measured number, and the stated range ends above it.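

Stereochemistry alone gives an 11-fold lower number from compound 1 to compound 3 (1.05 log units; beyond the scatter) in this assay with atoms and bonds unchanged, so the drawn configuration of the shared core matters in this read-out, which the earlier compounds could not show. The inverted saturated ring carbon cannot be credited with the whole step, because the second stereo element is undefined in one compound: the fact that one of compounds 1 and 3 is drawn with a defined configuration and the other without, at the place where they differ.

On these data alone, the separate contribution of each stereocentre stays open. So does whether an amine or a carboxylic acid on the shared core would move the number as far as this stereochemical change.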